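Aryl variation at one end of the series

A few compounds are considered here, and "the series" means these few. Any claim that something is new, unique, unknown or untested is made for them only; others in the source may bear on it.

Measured compounds:
compound 1 `COc1ccc(-c2cc(COC(Cc3cn(C4CCN(Cc5ccc([N+](=O)[O-])cc5)CC4)nn3)c3ccc(Br)cc3)on2)cc1` — > 25000 nM
compound 2 `N#Cc1ccc(-c2cc(COC(Cc3cn(C4CCN(Cc5ccc([N+](=O)[O-])cc5)CC4)nn3)c3ccc(Br)cc3)on2)cc1` — > 25000 nM
compound 3 `O=[N+]([O-])c1ccc(CN2CCC(n3cc(CC(OCc4cc(-c5ccccc5Br)no4)c4ccc(Br)cc4)nn3)CC2)cc1` — > 25000 nM

In a functional assay on HCT-116 cells (Homo sapiens) for cytotoxicity, with a stated time of 48 h (on this read-out lower numbers stand for stronger inhibition and higher numbers for weaker inhibition), compound 1 gives > 25000 nM, which is a limit of the assay rather than a number. Compound 2 likewise gives > 25000 nM, a limit. Compound 3 gives > 25000 nM, again a limit. All three values sit at the limit of > 25000 nM in this assay, at which 3 of the 3 values shown sit, so compound 3 stands where every other measured compound stands: at the limit, with no number to rank it.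

The steps among these compounds, a step that the two limits leave unreadable from compound 1 to compound 2, a step that the two limits leave unreadable from compound 1 to compound 3 and a step that the two limits leave unreadable from compound 2 to compound 3, are therefore unreadable in size and direction; each joins two limits.

Compound 4 `O=[N+]([O-])c1ccc(CN2CCC(n3cc(CC(OCc4cc(-c5ccccc5F)no4)c4ccc(Br)cc4)nn3)CC2)cc1` is not yet measured. It differs from compound 3 by fluoro in place of bromo on an aromatic carbon. Among the measured compounds shown here, none of the measured steps can be read, so no step of known size bears on this change, and no direction can be expected beyond the scatter. Since compound 3 gives > 25000 nM, compound 4 is expected to remain at the limit as well, and the expected step that the limit leaves unreadable from compound 3 to compound 4 is nominal only. The estimate for compound 4 in this assay is 40000 nM, with a range from 15000 nM to 120000 nM.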

Compound 4, half-maximal inhibitory concentration: 9000 nM
Compound 4: middle estimate off by 4.4-fold (0.65 log units), on the high side; measured number below the stated range.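

In this assay, among the compounds shown here, fluoro in place of bromo on an aromatic carbon, ortho to a large group, gives an at least 2.7-fold lower number from compound 3 to compound 4 (0.44 log units; beyond the scatter), so this single-atom change is the first with a readable direction. The 2-fluorophenyl group also separates compound 4 from the two compounds carrying other aryl groups, with an at least 2.7-fold lower number from compound 2 to compound 4 (0.44 log units; beyond the scatter) and an at least 2.7-fold lower number from compound 1 to compound 4 (0.44 log units; beyond the scatter), while compound 3 goes against any reading that a 2-substituted phenyl group is enough on its own, since 2-bromophenyl leaves it at the limit. All three steps give only a minimum size, and the steps among compounds 1, 2 and 3 cannot be read, because each of those compounds has a limit rather than a number: the limit of > 25000 nM in this assay, at which 3 of the 4 values shown sit.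

The compounds shown leave open whether chloro, methyl or an amine at this same place would sit with fluoro or with bromo, and how an unsubstituted phenyl group would compare. As far as these compounds go, the true size of the change from bromo to fluoro also remains open, and a single compound off the limit does not establish a trend across the series.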